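The source may hold more compounds than are shown below. What is called first, only, known or untested is meant among the compounds shown, and "the series" means these compounds.

Three compounds have been measured so far in an ADME assay on L6 cells (Rattus norvegicus) for cytotoxicity, read by resazurin assay, with a stated time of 70 h; on this read-out higher numbers stand for weaker inhibition and lower numbers for stronger inhibition:

- compound 1 `CC1=CC(C)(C)N(Cc2ccc(Cl)cc2)c2ccc(O)cc21` gives 7900 nM
- compound 2 `COc1ccc(CN2c3ccc(O)cc3C(C)=CC2(C)C)cc1` gives 6200 nM
- compound 3 `CC(=O)Oc1ccc2c(c1)C(C)=CC(C)(C)N2Cc1ccc(Cl)cc1` gives 22000 nM

Compound 1, at 7900 nM, is the reference point here. Its nearest neighbour is reached by a 1.3-fold lower number from compound 1 to compound 2 (0.11 log units; within the scatter) and its furthest by a 2.8-fold higher number from compound 1 to compound 3 (0.44 log units; beyond the scatter).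

Compound 4 `CC1=CC(C)(C)N(Cc2ccncc2)c2ccc(O)cc21` has not yet been measured. It differs from compound 1 in one place: pyridin-4-yl in place of 4-chlorophenyl on a saturated chain carbon bound to a nitrogen on an aromatic ring in a ring.

Two measured steps offer some guidance. Methoxy in place of chloro on an aromatic carbon gave a 1.3-fold lower number from compound 1 to compound 2 (0.11 log units; within the scatter), so that change to the same ring left the number within the scatter. Acetyl in place of hydrogen on an oxygen on an aromatic ring gave a 2.8-fold higher number from compound 1 to compound 3 (0.44 log units; beyond the scatter), a modest step toward weaker inhibition at another part of the molecule. For the measured compounds named here, no measured compound replaces the ring itself, so these steps guide only loosely and the range must stay wide.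

In this assay the step expected is a 2.3-fold higher number from compound 1 to compound 4 (0.36 log units; beyond the scatter) and it is a modest one toward weaker inhibition. For compound 4 the estimate is 18000 nM, with an expected range from 7000 nM to 50000 nM in this read-out.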

Compound 4, half-maximal inhibitory concentration: 13000 nM
Compound 4: the middle estimate sits 1.4-fold (0.14 log units) above what was measured, and the stated range covers the measured number.
By their numbers in this assay, from the lowest: compounds 2, 1, 4 and 3 (each within the scatter of the next, the first and the last beyond it).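

In this assay, the exchange at this saturated chain carbon gives a 1.6-fold higher number from compound 1 to compound 4 (0.22 log units; within the scatter), so here the whole 4-chlorophenyl ring gives way to pyridin-4-yl without a shift beyond the scatter. The earlier step at this part of the molecule, a 1.3-fold lower number from compound 1 to compound 2 (0.11 log units; within the scatter), only swapped chloro for methoxy on an otherwise unchanged ring, whereas this one removes the chlorine, puts a nitrogen into the ring and adds a hydrogen-bond acceptor, and the number still holds within the scatter. Nothing available explains why the number stays within the scatter after this exchange.

For the compounds shown here, all the groups at this place so far are six-membered aromatic rings, so it remains open whether the number would hold with a ring that is not aromatic, such as cyclohexyl, or with a plain butyl chain or a chain ending in an amine. From the compounds shown here alone, it is also open whether pyridin-3-yl would behave like pyridin-4-yl, and whether the acetyl on the oxygen would shift the number from compound 4 as it does from compound 1, as seen in a 2.8-fold higher number from compound 1 to compound 3 (0.44 log units; beyond the scatter).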